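The compounds below may be only part of what the source reports. "The series", "measured", "known", "first", "only" and "open" are said of these compounds alone.

Compound 1 `CCOC(=O)C12C(=O)OCC=C1COC2c1ccc(Cl)c(Cl)c1` gives 72400 nM in a functional assay on HeLa cells (Homo sapiens) for cytotoxicity, read by MTT assay; on this read-out lower numbers stand for stronger inhibition and higher numbers for weaker inhibition.
Compound 2 `CCOC(=O)C12C(=O)OCC=C1COC2c1ccc(OC)c(OC)c1` gives 10000 nM in this assay.
Compound 3 `CCOC(=O)C12C(=O)OCC=C1COC2c1cc(OC)cc(OC)c1` gives 16000 nM in this assay.

Of the three numbers measured in this assay, compound 3 stands second highest. Its nearest neighbour is compound 2, whose number is lower, but the gap between the two lies within the usual scatter of repeated measurements and so carries no order. The furthest is compound 1, whose number is higher than that of compound 3 by a gap that lies beyond the scatter.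

Compound 4 `CCOC(=O)C12C(=O)OCC=C1COC2c1cc(OC)c(OC)c(OC)c1` has not yet been measured in this assay. It differs from compound 3 by methoxy in place of hydrogen on an aromatic carbon. For the measured compounds named here, no step between two measured compounds matches this change, so the size of the step can only be judged from what the measured compounds show: compound 2 and compound 3, which both carry two methoxy groups on the aromatic ring, give numbers within the scatter of each other, and compound 1 without methoxy groups gives the highest number.

On that basis the step from compound 3 to compound 4 is expected to be a 1.5-fold lower number from compound 3 to compound 4 (0.16 log units; within the scatter), that is, no change beyond the scatter. Compound 4 is therefore estimated to give 11000 nM in this assay, with a range from 3500 nM to 35000 nM.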

Compound 4, half-maximal inhibitory concentration: 5400 nM
For compound 4 the middle estimate is 2.0-fold (0.31 log units) above the measured one; the measured number falls inside the stated range.
By their numbers in this assay, from the lowest: compounds 4, 2 and 3 (each within the scatter of the next, the first and the last beyond it); then compound 1.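

In this assay, for the compounds shown here, methoxy in place of hydrogen on the aromatic carbon ortho to two methoxy groups and para to a large group gives a 3.0-fold lower number from compound 3 to compound 4 (0.47 log units; beyond the scatter) and thus supplies the first single-place step here that clears the scatter, showing that this position responds to substitution. The other route to the same three-methoxy ring gives a 1.9-fold lower number from compound 2 to compound 4 (0.27 log units; within the scatter) and stays within the scatter, so the added methoxy has a readable effect only when compound 3 is the starting point, and compound 2 goes against any rule that a third methoxy always lowers the number. No evidence is available to explain the step at this position.

Whether the effect belongs to methoxy itself stays open, since the compounds shown do not place a hydroxyl, an ethoxy group, an amine or a fluorine on that aromatic carbon. Also open, going by these compounds, is whether the step would hold if the ethyl ester on the shared core gave way to a carboxylic acid or an amide.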